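The compounds below may be only part of what the source reports. "The series", "measured", "known", "first", "only" and "open" are said of these compounds alone.

Measured so far: compound 1 `Nc1cc(C2CCCC2)nc2ccc(NC(=O)/C=C/c3ccc(C(F)(F)F)cc3)cc12` gives 0.8 nM; compound 2 `CC(C)c1cc(N)c2cc(NC(=O)/C=C/c3ccc(C(F)(F)F)cc3)ccc2n1` gives 2.1 nM.

In an assay on isolated protein for displacement of a labelled ligand from melanin-concentrating hormone receptor 1 (Homo sapiens) (a higher number here means a weaker inhibitor, a lower number a stronger inhibitor), compound 2 stands at the higher of the two numbers, compound 1 being the nearer. Among the measured compounds shown here, the only step seen, a 2.6-fold higher number from compound 1 to compound 2 (0.42 log units; beyond the scatter), is modest. Compound 3 `CCC(C)c1cc(N)c2cc(NC(=O)/C=C/c3ccc(C(F)(F)F)cc3)ccc2n1` differs from compound 2 by methyl in place of hydrogen on a saturated chain carbon, two bonds along the chain from an aromatic carbon. For the measured compounds named here, no measured pair matches this change; the one step above bears on it only loosely, and the change runs the opposite way, from isopropyl back toward the cyclopentyl of compound 1. A small step toward a lower number is therefore expected, a 1.5-fold lower number from compound 2 to compound 3 (0.18 log units; within the scatter), at or just beyond the scatter. Compound 3 is estimated at 1.4 nM, range 0.6 nM to 3.5 nM.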

Compound 3, half-maximal inhibitory concentration: 0.3 nM
Compound 3: the middle estimate sits 4.7-fold (0.67 log units) above what was measured, outside the stated range (below it).
By their numbers in this assay, from the lowest: compound 3; then compound 1; then compound 2.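

In this assay, the isopropyl to sec-butyl change gives a 7.0-fold lower number from compound 2 to compound 3 (0.85 log units; beyond the scatter) and so has a clear effect on this chain. The open-chain sec-butyl also outdoes the ring, with a 2.7-fold lower number from compound 1 to compound 3 (0.43 log units; beyond the scatter), so the numbers do not run in a simple line from isopropyl to cyclopentyl, and compound 3 now holds the lowest number of the three. Nothing available accounts for this order.

Still open, on these data alone, is whether the lower number holds with a longer chain or with a hydroxyl group on the same carbon. The compounds shown also leave open how a tert-butyl group would compare.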